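A Lactam Replaced by an Aminopyrimidine Ring

The source may hold more compounds than are shown below. What is called first, only, known or untested is meant among the compounds shown, and "the series" means these compounds.

In an assay on C6 cells for antagonist activity at prostaglandin E2 receptor EP2 subtype (Homo sapiens) (on this read-out lower numbers stand for stronger inhibition and higher numbers for weaker inhibition), two compounds have been measured:
Compound 1, `Cc1cc2ccccc2n1CCNC(=O)C1CCC(c2ncccn2)CC1`: 380 nM
Compound 2, `Cc1cc2ccccc2n1CCNC(=O)C1CCC(=O)N1`: > 1000 nM

Compound 2 stands at the limit of > 1000 nM in this assay, at which 1 of the 2 values shown sits, so for it only a limit of this assay and no number is known. Compound 3, `Cc1cc2ccccc2n1CCNC(=O)c1cnc(N)nc1`, differs from compound 2 by 2-aminopyrimidin-5-yl in place of 5-oxopyrrolidin-2-yl on a carbonyl carbon. Within the data shown here, no step between two measured compounds differing in one place is available, so no measured size can guide this change. Compound 3 is expected to remain weak, with a step that the limit leaves unreadable from compound 2 to compound 3 estimated as a step not clearly beyond the scatter. Compound 3 is expected to give 1500 nM, in a range from 500 nM to 5000 nM.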

Compound 3, antagonist equilibrium constant: > 1000 nM
Compound 3 ended at the assay's limit (the forecaster's own chance of this, stated with the estimate: 55%); the middle value lies beyond the limit too.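

No step can be read from compound 2 to compound 3, as both stand at a limit and not at a number: the limit of > 1000 nM in this assay, at which 2 of the 3 values shown sit.

From the compounds shown here alone, whether 2-aminopyrimidin-5-yl does better or worse than 5-oxopyrrolidin-2-yl in this assay stays open.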